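A Biphenyl Amide Traded for a Cyclopropyl Amide

The compounds below may be only part of what the source reports. "The series", "measured", "known", "first", "only" and "open" are said of these compounds alone.

Compound 1 `O=C(COc1ccc2cc(C(O)(C(F)(F)F)C(F)(F)F)c(O)cc2c1)Nc1ccc(-c2ccccc2)cc1` carries a biphenyl group on the amide nitrogen of its side chain. In an assay on isolated protein for inhibition of receptor-type tyrosine-protein phosphatase C (Homo sapiens), read by spectrophotometry (on this read-out higher numbers stand for weaker inhibition and lower numbers for stronger inhibition), compound 1 gives 3400 nM, the only numerical result so far. Compound 2 `Oc1cc(-c2ccccc2)ccc1C(O)(C(F)(F)F)C(F)(F)F`, a small fragment that keeps only the phenyl-bearing core, reaches no number in this assay but only a limit of > 500000 nM, and that limit is recorded as the limit of > 500000 nM in this assay, at which 1 of the 2 values shown sits.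

Compound 3 `O=C(COc1ccc2cc(C(O)(C(F)(F)F)C(F)(F)F)c(O)cc2c1)NC1CC1` keeps the core and side chain of compound 1 and differs in one place: cyclopropyl in place of 4-phenylphenyl on an amide-type nitrogen. Going by the values given here, no measured pair shows the effect of such a change. Since compound 2 shows that the bare core gives nothing measurable, much of the binding seen for compound 1 is expected to rest on the larger amide group, and the step from compound 1 to compound 3 in this assay is expected to be a 7.4-fold higher number from compound 1 to compound 3 (0.87 log units; beyond the scatter), toward weaker inhibition, beyond the scatter. Compound 3 is expected to give about 25000 nM, between 6000 nM and 150000 nM.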

Compound 3, half-maximal inhibitory concentration: > 20000 nM
Compound 3: no number, only a limit; the forecaster's own chance of this, stated with the estimate: 20%; the middle value lies beyond the limit too.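

In this assay, cyclopropyl in place of 4-phenylphenyl on an amide-type nitrogen gives an at least 5.8-fold higher number from compound 1 to compound 3 (0.76 log units; beyond the scatter), toward weaker inhibition. The reading for compound 3 is a limit and not a number: the limit of > 20000 nM in this assay, at which 1 of the 3 values shown sits. This is the first change in one place among the compounds shown, and it tells that the core and side chain of compound 1 are not enough to keep its inhibition when only a cyclopropyl group sits on this nitrogen.

As far as these compounds go, the full size of the step stays unknown, and so does the real reading of compound 3. From the compounds shown here alone, it is also open how much of the 4-phenylphenyl group is needed, for instance whether a benzyl group or a hexyl chain on this nitrogen would keep the inhibition seen with compound 1.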